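Replacing the 4-methylphenyl of compound 2

This account rests on a few compounds, and the source may have more. Where it says the series, first, only, none or still open, it means among the compounds named here.

Compound 1 (`Cn1c(=O)c(S(=O)(=O)c2ccc(C(=O)O)cc2)cc2cnc(Nc3ccc4[nH]ccc4c3)nc21`) gives 10000 nM
Compound 2 (`Cc1ccc(S(=O)(=O)c2cc3cnc(Nc4ccc5[nH]ccc5c4)nc3n(C)c2=O)cc1`) gives 750 nM

Compound 2 has the lower number of the two in a functional assay on DU-145 cells (Homo sapiens) for inhibition, read by trypan blue exclusion, with a stated time of 72 h (a higher number here means a weaker inhibitor, a lower number a stronger inhibitor), and is the starting point here. Compound 3 (`Cn1c(=O)c(S(=O)(=O)c2ccc(F)cc2[N+](=O)[O-])cc2cnc(Nc3ccc4[nH]ccc4c3)nc21`) carries 4-fluoro-2-nitrophenyl in place of 4-methylphenyl on a sulfonyl sulfur. Among the compounds with values here, the one measured step is a 13-fold lower number from compound 1 to compound 2 (1.12 log units; beyond the scatter) and it is large, with methyl entering for carboxy on an aromatic carbon. Within the data shown here, compound 3 gives up that methyl, and no measured step covers 4-fluoro-2-nitrophenyl itself. For compound 3 the expected change is a 2.0-fold higher number from compound 2 to compound 3 (0.30 log units; within the scatter) and so a modest move toward a higher number. The estimate for compound 3 is 1500 nM (from 400 nM to 6000 nM).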

Compound 3, half-maximal inhibitory concentration: 1500 nM
For compound 3 middle estimate and measured number coincide at the digits printed; low and high end bracket the measured number.
By their numbers in this assay, from the lowest: compounds 2 and 3 (each within the scatter of the next); then compound 1.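

With a 2.0-fold higher number from compound 2 to compound 3 (0.30 log units; within the scatter) in this assay this position tolerates a larger aryl group carrying both fluoro and nitro, and the 4-methyl of compound 2 is not required to stay within the scatter. Compound 3 also keeps clear of the carboxylated compound, with a 6.7-fold lower number from compound 1 to compound 3 (0.82 log units; beyond the scatter) as the step, so among these three only the 4-carboxyphenyl stands apart. Nothing available explains these results. The compounds shown leave open how the fluoro and the nitro each count when alone on the ring, and how an amine or a methyl ester would fare on this phenyl.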